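The compounds below may be only part of what the source reports. "The series", "measured", "known", "first", "only" and "open" are said of these compounds alone.

Three compounds in this series have been examined in an assay on cells for displacement of a labelled ligand from adenosine receptor A1 (Homo sapiens), read by scintillation counting, with a stated time of 3 h (on this read-out higher numbers stand for weaker inhibition and lower numbers for stronger inhibition), and compound 3, with the structure `COc1ccc(-c2cn3c(=O)n(-c4ccccc4)nc3c(=O)[nH]2)cc1`, is the starting point here. In this assay compound 3 gives > 30000 nM, which is a limit of the assay rather than a number. Compound 2, with the structure `O=c1[nH]c(-c2ccccc2)cn2c(=O)n(-c3ccccc3)nc12`, gives > 30000 nM in this assay, again a limit. Compound 1, with the structure `CC(C)COc1ccc(-c2cn3c(=O)n(-c4ccccc4)nc3c(N)n2)cc1`, has "not determined" (no result reported) in this assay. The step from compound 2 to compound 3, methoxy in place of hydrogen on an aromatic carbon, reads a step that the two limits leave unreadable from compound 2 to compound 3, so nothing can be drawn from it. What is known is the limit of > 30000 nM in this assay, at which 2 of the 3 values shown sit.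

Compound 4, with the structure `O=c1[nH]c(-c2ccc(O)cc2)cn2c(=O)n(-c3ccccc3)nc12`, differs from compound 3 by hydrogen in place of methyl on an oxygen on an aromatic ring. For the measured compounds named here, no measured step bears on this change, and the only neighbour sits at a limit. The step from compound 3 to compound 4 is therefore expected to be a step that the limit leaves unreadable from compound 3 to compound 4, in effect no readable change. Compound 4 is estimated at 40000 nM, with a range from 10000 nM to 150000 nM.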

Compound 4, inhibition constant: 616 nM
The estimate for compound 4 lay 65-fold (1.81 log units) above the measured number, outside the stated range (below it).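

In this assay, changing 4-methoxyphenyl to 4-hydroxyphenyl gives an at least 48-fold lower number from compound 3 to compound 4 (1.68 log units; beyond the scatter), so at this position, it makes a large difference whether the oxygen carries a hydrogen or a methyl. Placing hydroxy on the aromatic carbon that carries only hydrogen in the unsubstituted compound gives an at least 48-fold lower number from compound 2 to compound 4 (1.68 log units; beyond the scatter), so the hydroxy compound also stands well clear of the compound with no group there. The step between the two earlier compounds cannot be read, and hydroxy is the only group here that brings this position to a real number rather than a limit: the limit of > 30000 nM in this assay, at which 2 of the 4 values shown sit.

The compounds shown leave open whether hydroxy is specifically required on this carbon, or whether an amine or a carboxylic acid there would give a similar number. They also give no explanation for the large size of these steps.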